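Methylcarbamoyl isomers: from compound 3 to compound 4

The source may report more compounds than this note shows. Statements on the series, on what has been measured and on what is new or still open speak of the compounds shown alone.

In a physicochemical assay for lipophilicity, at pH 7.4 (on this read-out lower numbers stand for lower lipophilicity and higher numbers for higher lipophilicity), compound 1 `O=C(Nc1ccc2[nH]ccc2n1)[C@H]1CCCN1C(=O)C1(c2cccc(Cl)c2)CCCC1` gives 5.9 and compound 2 `O=C1Cc2cc(NC(=O)[C@H]3CCCN3C(=O)C3(c4cccc(Cl)c4)CCCC3)ccc2N1` gives 5 while compound 3 `CNC(=O)c1cccc(NC(=O)[C@H]2CCCN2C(=O)C2(c3cccc(Cl)c3)CCCC2)c1` gives 5.5 on the same scale. Compound 3 is therefore second highest of the three, lower than compound 1 and higher than compound 2.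

Compound 4 `CNC(=O)c1ccc(NC(=O)[C@H]2CCCN2C(=O)C2(c3cccc(Cl)c3)CCCC2)cc1` carries 4-(methylcarbamoyl)phenyl in place of 3-(methylcarbamoyl)phenyl on an amide-type nitrogen. The counted difference is 4-(methylcarbamoyl)phenyl in place of 3-(methylcarbamoyl)phenyl on an amide-type nitrogen with the same atoms joined differently.

The measured steps at this place are a number 0.90 log units lower from compound 1 to compound 2 (beyond the scatter) and a number 0.40 log units lower from compound 1 to compound 3 (beyond the scatter) and also a number 0.50 log units higher from compound 2 to compound 3 (beyond the scatter) in turn. All three are modest and beyond the scatter, but each swaps one group for a differently built one. Among the compounds with values here, no measured pair keeps the same atoms and joins them differently, so these steps give only a loose guide to size. Compound 3 is the closest reference, with its 5.5 as the anchor.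

The expected change is no change at the digits printed from compound 3 to compound 4 (within the scatter) with no step beyond the scatter foreseen. Compound 4 is estimated at 5.5 with an expected range of 5.1 to 5.9 in this assay terms.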

Compound 4, distribution coefficient: 5.3
The estimate for compound 4 lay 0.20 log units above the measured number; the range from low to high includes it.
By their numbers in this assay, from the lowest: compounds 2, 4 and 3 (each within the scatter of the next, the first and the last beyond it); then compound 1.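

Joining the same atoms differently, with 4-(methylcarbamoyl)phenyl in place of 3-(methylcarbamoyl)phenyl on an amide-type nitrogen, gives a number 0.20 log units lower from compound 3 to compound 4 (within the scatter) in this assay and so separates the two isomers by no more than the usual scatter. Measured against the other two groups at this place, the new isomer gives a number 0.30 log units higher from compound 2 to compound 4 (within the scatter) and a number 0.60 log units lower from compound 1 to compound 4 (beyond the scatter) on this read-out, whereas a number 0.50 log units higher from compound 2 to compound 3 (beyond the scatter) had been the step for the earlier isomer. No measurement is available to explain these numbers.

On these data alone, whether the attachment point matters as little with a carboxylic acid or an aminomethyl group in place of methylcarbamoyl remains open. So does the effect of a longer chain on the amide nitrogen of that group.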